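Working notes: ethylamino to benzylamino on the shared core

The source may report more compounds than this note shows. Statements on the series, on what has been measured and on what is new or still open speak of the compounds shown alone.

Values in a functional assay on the whole organism with Rattus norvegicus as the target; on this read-out higher numbers stand for an effect only at larger amounts of compound and lower numbers for an effect already at smaller amounts:
compound 1 `CNc1cc(OC)c(C(=O)NC2CCN(Cc3ccccc3)C2)cc1Cl`: 0.016 mg/kg
compound 2 `CCNc1cc(OC)c(C(=O)NC2CCN(Cc3ccccc3)C2)cc1Cl`: 0.1 mg/kg
compound 3 `COc1cc(NCc2ccccc2)c(Cl)cc1C(=O)NC1CCN(Cc2ccccc2)C1`: not yet measured

Of the two numbers in this assay, compound 2 holds the higher, at 0.1 mg/kg. The change to compound 3 is phenyl in place of methyl on a saturated chain carbon bound to a nitrogen on an aromatic ring. Going by the values given here, one measured step bears on it, at the same place: methyl in place of hydrogen, a 6.3-fold higher number from compound 1 to compound 2 (0.80 log units; beyond the scatter), modest but beyond the scatter. Among the compounds with values here, a single step fixes no trend, and no aromatic group has yet been measured at this place, so the uncertainty is wide. Going by that step, a further move to a higher number of similar size is expected. The expected change is a 5.0-fold higher number from compound 2 to compound 3 (0.70 log units; beyond the scatter). For compound 3 the estimated value is 0.5 mg/kg, with an expected range of 0.1 mg/kg to 2.5 mg/kg.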

Compound 3, dose for half-maximal effect: > 30 mg/kg
Compound 3 ended at the assay's limit; the forecaster's own chance of this, stated with the estimate: 15%; at least 60-fold (1.77 log units) between middle value and limit.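

Compound 3 gives > 30 mg/kg in this assay, which is a limit of the assay and not a number: the limit of > 30 mg/kg in this assay, at which 1 of the 3 values shown sits. At this place the step with phenyl in place of methyl is an at least 300-fold higher number from compound 2 to compound 3 (2.47 log units; beyond the scatter), and with phenyl in place of hydrogen it is an at least 1800-fold higher number from compound 1 to compound 3 (3.27 log units; beyond the scatter); both are large, whereas a 6.3-fold higher number from compound 1 to compound 2 (0.80 log units; beyond the scatter) is modest. The three compounds run in one direction from methylamino through ethylamino to benzylamino, none going against it, and the phenyl brings far more than a further increment of the first step.

Going by these compounds, whether this belongs to the aromatic ring or to any longer group stays open: a propyl chain, or cyclohexyl in place of phenyl, would separate the two. On these data alone, how a free amino group or a pyridyl ring at this place would read is also open.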